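Chloro to Cyano on the Aryl Ring of Compound 3

The source may hold more compounds than are shown below. What is called first, only, known or untested is meant among the compounds shown, and "the series" means these compounds.

Compound 3 `O=C1Nc2ccccc2/C1=C/c1ccc(-c2cn(-c3ccccc3Cl)nn2)cc1` carries a 2-chlorophenyl on an aromatic nitrogen of the shared core. In a functional assay on MKN-45 cells (Homo sapiens) for inhibition, read by CCK-8 assay, with a stated time of 24 h (on this read-out higher numbers stand for weaker inhibition and lower numbers for stronger inhibition), compound 3 gives only a limit, > 20000 nM. Compound 1 `O=C1Nc2ccccc2/C1=C/c1ccc(-c2cn(-c3ccccc3F)nn2)cc1` gives 12500 nM in this assay. Compound 2 `O=C1Nc2ccccc2/C1=C/c1ccc(-c2cn(-c3cccc(F)c3)nn2)cc1` gives only a limit in this assay, > 20000 nM. The two steps into compound 3 read an at least 1.6-fold higher number from compound 1 to compound 3 (0.20 log units; that floor lies within the scatter) and a step that the two limits leave unreadable from compound 2 to compound 3, both shaped by the limit of > 20000 nM in this assay, at which 2 of the 3 values shown sit. Compound 4 `N#Cc1ccccc1-n1cc(-c2ccc(/C=C3\C(=O)Nc4ccccc43)cc2)nn1` differs from compound 3 by cyano in place of chloro on an aromatic carbon. Going by the values given here, no measured step involves a cyano group, and the steps that end at compound 3 carry no readable size, so nothing points in either direction. Compound 4 is therefore expected to stay near the same limit, an estimated step of a number no higher from compound 3 to compound 4 (the limit leaves the size open), giving an estimate of 20000 nM with a range from 8000 nM to 50000 nM.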

Compound 4, half-maximal inhibitory concentration: 14600 nM
Compound 4: middle estimate off by 1.4-fold (0.14 log units), on the high side, within the range that was stated.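

In this assay cyano at this place, ortho to a large group, gives compound 4 a measured value where the chloro of compound 3 gave only a limit. The floors read an at least 1.3-fold lower number from compound 3 to compound 4 (0.13 log units; that floor lies within the scatter) and an at least 1.3-fold lower number from compound 2 to compound 4 (0.13 log units; that floor lies within the scatter) and the step from the fluoro compound reads a 1.2-fold higher number from compound 1 to compound 4 (0.07 log units; within the scatter) so cyano and fluoro cannot be told apart here. The true size of the change from chloro to cyano stays unreadable, and the limit remains the main feature of this small set: the limit of > 20000 nM in this assay, at which 2 of the 4 values shown sit.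

Going by these compounds, whether an amine or a carboxylic acid at this place would move the number beyond the scatter remains open.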